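The source may hold more compounds than are shown below. What is called first, only, known or untested is meant among the compounds shown, and "the series" means these compounds.

In a functional assay on RAW264.7 cells (Mus musculus) for inhibition, read by Griess assay, with stated times of 1 h and 24 h (on this read-out lower numbers stand for stronger inhibition and higher numbers for weaker inhibition), compound 1 `O=C1OC(Cc2nc(Cc3ccccc3)no2)c2ccccc21` returns > 10000 nM as a limit and not a number. Within the data shown here, compound 2 `CCCOc1ccc(C(O)C2OC(=O)c3c(OC)cc(OC)cc32)cc1` gives 9260 nM in this assay and so holds the only actual number so far. Compound 3 `COCCCCOc1ccc(C(O)C2OC(=O)c3c(OC)cc(OC)cc32)cc1` differs from compound 2 by methoxymethyl in place of hydrogen on a saturated chain carbon, three bonds along the chain from an oxygen on an aromatic ring and carries methoxymethyl in place of hydrogen on a saturated chain carbon, three bonds along the chain from an oxygen on an aromatic ring. Cut one bond further out, this reads propyl to 4-methoxybutyl. Among the measured compounds shown here, no measured step shows what such a change does, so no shift beyond the scatter is expected in this assay, and the estimated change is a 1.3-fold lower number from compound 2 to compound 3 (0.12 log units; within the scatter) on that basis. The estimate for compound 3 is 7000 nM with an expected range from 3000 nM to 10000 nM in this read-out.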

Compound 3, half-maximal inhibitory concentration: 8210 nM
Beside the measured number, compound 3's estimate is 1.2-fold (0.07 log units) below it; the measured number falls inside the stated range.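

In this assay the series now has its first readable step at this position: a 1.1-fold lower number from compound 2 to compound 3 (0.05 log units; within the scatter), with methoxymethyl in place of hydrogen on a saturated chain carbon, three bonds along the chain from an oxygen on an aromatic ring. Read one bond further out, propyl to 4-methoxybutyl, the longer ether chain leaves the read-out without a shift beyond the scatter. Compound 1 differs from the others in more than one place and stands at a limit of the assay, so it offers no comparison: the limit of > 10000 nM in this assay, at which 1 of the 3 values shown sits.

From the compounds shown here alone, whether an amine or a carboxylic acid at the end of this chain would move the number beyond the scatter remains open. A single step also cannot show how a phenyl ring or a much longer alkyl chain would behave here.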